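The compounds below may be only part of what the source reports. "The series", "measured", "known", "first", "only" and "open" are said of these compounds alone.

In a functional assay on HeLa cells (Homo sapiens) for inhibition, read by MTT assay, with a stated time of 72 h (a higher number here means a weaker inhibitor, a lower number a stronger inhibitor), compound 1 `COc1cc(NC(=O)/C=C/c2cccc(OCc3ccccc3)c2)cc(OC)c1OC` gives 2200 nM. Within the data shown here, compound 2 `C=C(Br)C(=O)Nc1cccc(/C=C/C(=O)Nc2cc(OC)cc(OC)c2)c1` gives 2200 nM, so compound 1 stands level with the only other measured compound. Compound 3 `COc1cc(NC(=O)/C=C/c2cccc(N)c2)cc(OC)c1OC` has not yet been measured. It carries amino in place of benzyloxy on an aromatic carbon, meta to a large group: amino in place of benzyloxy on an aromatic carbon. Among the measured compounds shown here, no measured pair shows this kind of change, so the expectation rests on the structural change alone. A weakening beyond the scatter in this assay is expected, a 3.6-fold higher number from compound 1 to compound 3 (0.56 log units; beyond the scatter). The estimate for compound 3 is 8000 nM, with an expected range from 2000 nM to 30000 nM.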

Compound 3, half-maximal inhibitory concentration: 53100 nM
Estimate against measurement, compound 3: 6.6-fold (0.82 log units) below; measured number above the stated range.
By their numbers in this assay, from the lowest: compounds 1 and 2 (each within the scatter of the next); then compound 3.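

In this assay, amino in place of benzyloxy on this aromatic carbon gives a 24-fold higher number from compound 1 to compound 3 (1.38 log units; beyond the scatter), the first step seen at this position, and a large one. Among these compounds, the position is therefore not indifferent to what it carries, which the level values of the earlier compounds could not show. No available evidence bears on why the number rose. This single step removes the benzyloxy group whole, so it cannot separate the loss of its aromatic ring from the arrival of the amino group. On these data alone, whether a methoxy or a benzylamino group here would stay close to compound 1 remains open.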